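Extending the alkoxy group of compound 2

The compounds below may be only part of what the source reports. "The series", "measured", "known", "first", "only" and "open" are said of these compounds alone.

Measured so far:
compound 1, `CCOc1nc(-c2nc3ccccc3n2C)cc(-c2ccccc2)c1C#N`, gives 364000 nM in a functional assay on aorta (Rattus norvegicus, strain Wister); a higher number here means a weaker inhibitor, a lower number a stronger inhibitor
compound 2, `COc1nc(-c2nc3ccccc3n2C)cc(-c2ccc(Cl)cc2)c1C#N`, gives 145000 nM in this assay

Compound 2 gives the lowest of the two numbers in this assay; its nearest neighbour is compound 1, whose number is higher by a gap beyond the usual scatter. Compound 1 and compound 2 differ in more than one place, so no single step can be read from the pair; their two values simply show that compound 2 is the stronger inhibitor of the two.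

Compound 3, `CCOc1nc(-c2nc3ccccc3n2C)cc(-c2ccc(Cl)cc2)c1C#N`, has not yet been measured. It keeps the shared core of compound 2 and changes only one point: methyl in place of hydrogen on a saturated chain carbon bound to an oxygen on an aromatic ring. Nothing measured here isolates that change on its own, so the expectation rests on compound 2 alone. A step of this kind is expected to stay small, probably toward a slightly higher number in this assay, but not clearly beyond the scatter. The step from compound 2 to compound 3 is expected to be a 1.4-fold higher number from compound 2 to compound 3 (0.14 log units; within the scatter). Compound 3 is therefore estimated at 200000 nM, with a likely range from 80000 nM to 500000 nM.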

Compound 3, half-maximal inhibitory concentration: 293000 nM
Beside the measured number, compound 3's estimate is 1.5-fold (0.17 log units) below it; the measured number falls inside the stated range.
By their numbers in this assay, from the lowest: compound 2; then compounds 3 and 1 (each within the scatter of the next).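

Among these compounds, with compound 3, the change from methoxy to ethoxy can be read on its own for the first time: in this assay the step is a 2.0-fold higher number from compound 2 to compound 3 (0.31 log units; beyond the scatter), a modest loss of inhibition from adding methyl in place of hydrogen on a saturated chain carbon bound to an oxygen on an aromatic ring. The same compound also isolates chloro in place of hydrogen on an aromatic carbon, with the ethoxy group held constant, and that step, a 1.2-fold lower number from compound 1 to compound 3 (0.09 log units; within the scatter), stays within the scatter, so on this ethoxy background the chloro group does not separate the two compounds. Nothing available here accounts for either step.

The compounds shown leave open whether a longer chain such as propoxy, a branched group such as isopropoxy, or an amine on the chain would continue this loss of inhibition or reverse it. They also leave open whether fluoro or methyl on that aromatic carbon would behave as chloro does, and whether the chloro step would be the same on a methoxy background.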